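Swapping tert-butyl for methylsulfanyl on the shared core

This account rests on a few compounds, and the source may have more. Where it says the series, first, only, none or still open, it means among the compounds named here.

Of the compounds shown here, three built on one shared core have been tested in a functional assay on Jurkat cells for inhibition of nuclear factor NF-kappa-B complex (Homo sapiens); on this read-out lower numbers stand for stronger inhibition and higher numbers for weaker inhibition. Compound 1 `CCOC(=O)c1cnc(C(F)(F)F)nc1NN1C(=O)C=C(C)C1=O` carries a trifluoromethyl group and gives 1000 nM. Compound 2 `CCOC(=O)c1cnc(C)nc1NN1C(=O)C=C(C)C1=O` carries a methyl group on the same aromatic carbon and gives 16000 nM. Compound 3 `CCOC(=O)c1cnc(C(C)(C)C)nc1NN1C(=O)C=C(C)C1=O` carries a tert-butyl group there and gives 1000 nM. Compound 3 thus stands level with compound 1, the pair together giving the lowest numbers of the three, and well apart from compound 2: a 16-fold lower number from compound 2 to compound 3 (1.20 log units; beyond the scatter), whereas no change at the digits printed from compound 1 to compound 3 (within the scatter).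

Compound 4 `CCOC(=O)c1cnc(SC)nc1NN1C(=O)C=C(C)C1=O` is the next step: methylsulfanyl in place of tert-butyl on an aromatic carbon. The measured steps show that this position matters: the exchange of methyl for trifluoromethyl (a 16-fold higher number from compound 1 to compound 2 (1.20 log units; beyond the scatter)) was large, while tert-butyl and trifluoromethyl behaved alike. Going by the values given here, no measured compound carries methylsulfanyl, so the direction must be guessed from these two outcomes; a moderate rise in this assay is expected, a 3.0-fold higher number from compound 3 to compound 4 (0.48 log units; beyond the scatter). The estimate for compound 4 is 3000 nM, with a range from 1000 nM to 10000 nM.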

Compound 4, half-maximal inhibitory concentration: 200 nM
The estimate for compound 4 lay 15-fold (1.18 log units) above the measured number; measured number outside the range, below it.
By their numbers in this assay, from the lowest: compound 4; then compounds 1 and 3 (each within the scatter of the next); then compound 2.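

The level shared by the trifluoromethyl and tert-butyl compounds turns out not to be the lowest this position can reach in this assay: methylsulfanyl gives a 5.0-fold lower number from compound 3 to compound 4 (0.70 log units; beyond the scatter) and, by the same size, a 5.0-fold lower number from compound 1 to compound 4 (0.70 log units; beyond the scatter). The distance from the methyl compound grows to an 80-fold lower number from compound 2 to compound 4 (1.90 log units; beyond the scatter), and heavy-atom count does not order these groups, since methylsulfanyl has fewer heavy atoms than tert-butyl yet gives the lower number, while methyl gives the highest. Nothing available explains why methylsulfanyl gives the lowest number here.

From the compounds shown here alone, it remains open whether the gain belongs to the sulfur atom or to the chain as a whole, which a methoxy group or a longer ethylsulfanyl chain on this carbon could separate. Also open, going by these compounds, is how an amine at this position would compare, and whether methylsulfanyl would give the same gain with another group in place of the ethoxycarbonyl group.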